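A few compounds are considered here, and "the series" means these few. Any claim that something is new, unique, unknown or untested is made for them only; others in the source may bear on it.

In an ADME assay on HEK-293T cells (Homo sapiens) for cytotoxicity, read by CCK-8 assay, with a stated time of 48 h (a higher number here means a weaker inhibitor, a lower number a stronger inhibitor), compound 2 (`COc1cccc(NC(=S)NCCNS(=O)(=O)c2ccc(-c3ccccc3Oc3ccc([N+](=O)[O-])cc3)s2)c1`) gives > 20000 nM, which is a limit of the assay and not a number. Its true value is therefore unknown. Compound 3 (`O=[N+]([O-])c1ccc(Oc2ccccc2-c2ccc(S(=O)(=O)NCCNC(=S)Nc3cccc(Cl)c3)s2)cc1`) keeps the rest of compound 2 and changes one group: chloro in place of methoxy on an aromatic carbon. In words, chloro takes the place of methoxy on an aromatic carbon, so 3-methoxyphenyl becomes 3-chlorophenyl. Within the data shown here, no measured pair shows what this swap does on its own. The nearest guide is compound 1 (`O=S(=O)(NCCNC(=S)Nc1cccc(Cl)c1)c1ccc(-c2ccccc2OCc2cccc(O)c2)s1`), which also carries 3-chlorophenyl but differs elsewhere and gives 17400 nM in this assay. On that basis, only a small shift towards a lower number is expected, not clearly beyond the usual scatter. The estimated change is an at least 1.1-fold lower number from compound 2 to compound 3 (0.04 log units; that floor lies within the scatter). For compound 3 the estimated value is 18000 nM, with an expected range of 9000 nM to 35000 nM.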

Compound 3, half-maximal inhibitory concentration: 4990 nM
Beside the measured number, compound 3's estimate is 3.6-fold (0.56 log units) above it; the measured number lies below the stated range.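

In this assay compound 2 gives > 20000 nM, which is a limit of the assay and not a number. With 3-chlorophenyl held constant, 4-nitrophenyl on the oxygen gives a real gain in cytotoxicity over 3-hydroxybenzyl (a 3.5-fold lower number from compound 1 to compound 3 (0.54 log units; beyond the scatter)), so that end of the molecule matters in this pair. The chloro-for-methoxy swap at the other end also moves the result beyond the scatter (an at least 4.0-fold lower number from compound 2 to compound 3 (0.60 log units; beyond the scatter)), the first sign that this single aromatic position matters, though that size is only a floor: the limit of > 20000 nM in this assay, at which 1 of the 3 values shown sits.

The compounds shown leave open whether a fluoro, a methyl or an amine at this position would behave like chloro or like methoxy. Nor do they show whether the swap acts the same way with 3-hydroxybenzyl on the oxygen: compound 1 has no methoxy partner.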